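This account rests on a few compounds, and the source may have more. Where it says the series, first, only, none or still open, it means among the compounds named here.

Measured so far:
- compound 1, `Cc1cccc(C(=O)NC(CCN(C)C)c2ccc(Cl)cc2)c1C`: 3630 nM
- compound 2, `Cc1cc(C)c(C(=O)NC(CCN(C)C)c2ccc(Cl)cc2)cc1C`: 1780 nM
- compound 3, `CN(C)CCC(OC(=O)Nc1ccc(C(C)(C)C)cc1)c1ccc(Cl)cc1`: 1820 nM

In an assay on NIH3T3 cells with Urotensin-2 receptor (Homo sapiens) as the target (a higher number here means that more compound is needed for the effect, a lower number that less compound is needed), compound 1 gives 3630 nM, the highest of the three numbers, so of these three it needs the most compound for the effect. Compound 3 gives 1820 nM, a lower number but one that stays within the scatter of repeated measurements, so the two cannot be told apart. Compound 2 gives 1780 nM, a lower number that lies just beyond the scatter.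

Compound 4, `Cc1ccccc1NC(=O)NC(CCN(C)C)c1ccc(Cl)cc1`, differs from compound 1 in one place: (2-methylphenyl)amino in place of 2,3-dimethylphenyl on a carbonyl carbon. In words, (2-methylphenyl)amino in place of 2,3-dimethylphenyl on a carbonyl carbon, so one hydrogen-bond donor enters where none was before. Among the measured compounds shown here, no pair of measured compounds isolates this kind of change, so no measured step can guide the size. The three measured values cluster closely despite their differences, which suggests a small step in this assay, pointing slightly toward a lower number but possibly none beyond the scatter. The expected step from compound 1 to compound 4 is a 1.5-fold lower number from compound 1 to compound 4 (0.16 log units; within the scatter). Compound 4 is therefore estimated at 2500 nM, with a likely range from 900 nM to 7000 nM.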

Compound 4, half-maximal effective concentration: 2290 nM
Beside the measured number, compound 4's estimate is 1.1-fold (0.04 log units) above it, and the stated range covers the measured number.
By their numbers in this assay, from the lowest: compounds 2, 3, 4 and 1 (each within the scatter of the next, the first and the last beyond it).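

In this assay, among the compounds shown here, the swap of 2,3-dimethylphenyl for (2-methylphenyl)amino on a carbonyl carbon is the first one-place comparison available (a 1.6-fold lower number from compound 1 to compound 4 (0.20 log units; within the scatter)). A hydrogen-bond donor can therefore enter at this position while compound 1 and compound 4 remain indistinguishable in this measurement, though this holds for this single pair only. No measured evidence bears on this result.

The swap also alters two things at once, since 2,3-dimethylphenyl carries one more methyl than 2-methylphenyl, so a (2,3-dimethylphenyl)amino group would be needed to separate the effect of the added nitrogen from that of the methyl. From the compounds shown here alone, whether this position stays as undemanding with a group of another kind, such as a benzylamino group with its longer link to the ring, also remains open.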